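The source may report more compounds than this note shows. Statements on the series, on what has been measured and on what is new or still open speak of the compounds shown alone.

Measured compounds in a functional assay on MCF7 cells (Homo sapiens) for cytotoxicity, read by MTT assay, with a stated time of 24 h; a higher number here means a weaker inhibitor, a lower number a stronger inhibitor:
- compound 1 `COc1cccc(/C=C2\SC(=O)N(Cc3ccc(C(=O)O)cc3)C2=O)c1` gives 58000 nM
- compound 2 `O=C(O)c1ccc(CN2C(=O)S/C(=C\c3cccnc3)C2=O)cc1` gives 100000 nM
- compound 3 `COc1cc(/C=C2\SC(=O)N(Cc3ccc(C(=O)O)cc3)C2=O)cc(OC)c1OC` gives 30000 nM

Within the data shown here, all three share a core that carries a carboxylic acid-bearing benzyl group on one side and an aromatic ring on a double-bonded chain carbon on the other; only that aromatic ring varies. Compound 2 shows the highest number of the three, but its gap to compound 1 is within the scatter, so the two cannot be ranked; compound 3 sits further off, with a number beyond the scatter below that of compound 2.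

Compound 4 `O=C(O)c1ccc(CN2C(=O)S/C(=C\c3cccs3)C2=O)cc1` differs from compound 2 in one place: thiophen-2-yl in place of pyridin-3-yl on a double-bonded chain carbon bound to a double-bonded ring carbon. Among the measured compounds shown here, the one measured step at this position, a 1.7-fold higher number from compound 1 to compound 2 (0.24 log units; within the scatter), shows that swapping one six-membered aromatic ring for another moved the number only within the scatter. With no measured thiophene to draw on, the step from compound 2 to compound 4 is expected to be modest, and on balance toward a lower number, as compounds 1 and 3 suggest that rings other than pyridin-3-yl here tend to read lower. Compound 4 is therefore estimated at 60000 nM, within 25000 nM to 150000 nM, an expected step of a 1.7-fold lower number from compound 2 to compound 4 (0.22 log units; within the scatter).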

Compound 4, half-maximal inhibitory concentration: 76000 nM
Compound 4: middle estimate off by 1.3-fold (0.10 log units), on the low side; the measured number falls inside the stated range.
By their numbers in this assay, from the lowest: compounds 3, 1, 4 and 2 (each within the scatter of the next, the first and the last beyond it).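

In this assay a five-membered aromatic ring, thiophen-2-yl, now stands at this place, on a double-bonded chain carbon bound to a double-bonded ring carbon, where the earlier compounds shown carry six-membered aromatic rings. The number stays within the scatter against both neighbours, pyridin-3-yl (a 1.3-fold lower number from compound 2 to compound 4 (0.12 log units; within the scatter)) and 3-methoxyphenyl (a 1.3-fold higher number from compound 1 to compound 4 (0.12 log units; within the scatter)), so for these compounds neither the smaller ring nor sulfur as its hetero atom separates compound 4 from compound 1 or compound 2. No measurement here offers a reason for this result.

The compounds shown leave open whether a saturated ring such as cyclohexyl at this place would read like these aromatic rings. They also leave open what a methyl ester would do in place of the carboxylic acid, which all four compounds carry.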